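Adding a second propyl to compound 3

This account rests on a few compounds, and the source may have more. Where it says the series, first, only, none or still open, it means among the compounds named here.

In a functional assay on KB 3-1 cells (Homo sapiens), with a stated time of 1 h (on this read-out lower numbers stand for an effect already at smaller amounts and higher numbers for an effect only at larger amounts of compound), compound 3 (`CCCOc1c(O)cc2oc(-c3ccccc3)cc(=O)c2c1O`) gives 2000 nM, within the scatter of compound 2 (`O=c1cc(-c2ccccc2)oc2cc(O)c(OCc3ccccc3)c(O)c12`) at 1800 nM. Compound 1 (`CC(=O)Oc1c(O)cc2oc(-c3ccccc3)cc(=O)c2c1O`) gives 11000 nM, the highest number of the three.

Compound 4 (`CCCOc1cc2oc(-c3ccccc3)cc(=O)c2c(O)c1OCCC`) differs from compound 3 by one change: propyl in place of hydrogen on an oxygen on an aromatic ring, or hydroxy to propoxy.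

Going by the values given here, no measured step makes this exact change, so the evidence is indirect. Replacing acetyl gave modest steps, a 6.1-fold lower number from compound 1 to compound 2 (0.79 log units; beyond the scatter) and a 5.5-fold lower number from compound 1 to compound 3 (0.74 log units; beyond the scatter), while exchanging phenyl for ethyl gave a 1.1-fold higher number from compound 2 to compound 3 (0.05 log units; within the scatter), within the scatter. These steps show only that the benzyl and propyl ethers sit together, and they say nothing direct about replacing a hydrogen.

With so little to suggest a large shift, the estimated step is a 1.3-fold lower number from compound 3 to compound 4 (0.12 log units; within the scatter), which is expected to stay within the scatter. The direction remains uncertain. For compound 4 the expected value is 1500 nM, with an estimated range from 450 nM to 6000 nM.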

Compound 4, half-maximal effective concentration: 1400 nM
The estimate for compound 4 lay 1.1-fold (0.03 log units) above the measured number; the range from low to high includes it.
By their numbers in this assay, from the lowest: compounds 4, 2 and 3 (each within the scatter of the next); then compound 1.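

In this assay, propyl in place of hydrogen on an oxygen on an aromatic ring leaves the number within the scatter (a 1.4-fold lower number from compound 3 to compound 4 (0.15 log units; within the scatter)). Going by these compounds alone, this is the first step that caps a free hydroxy, as the earlier steps only exchanged acetyl, benzyl and propyl on an oxygen that already carried a group. For this pair, then, hydroxy to propoxy is tolerated, and the hydrogen on this oxygen is not needed to hold the number in this range. No measurement shown accounts for this result.

Still open, from the compounds shown here alone, is whether a longer chain such as hexyl, or a chain ending in an amine or a carboxylic acid, would behave like propyl on this oxygen. Also open, going by these compounds, is what replacing the remaining hydroxy of compound 4 would do.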